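This account rests on a few compounds, and the source may have more. Where it says the series, first, only, none or still open, it means among the compounds named here.

Compound 1 `CS(=O)(=O)c1ccc(-c2cnc3[nH]cc(-c4nnc(-c5ccncc5)o4)c(=O)c3c2)cc1`: 18.4% in a functional assay on HeLa cells (Homo sapiens) for inhibition, read by MTT assay, with a stated time of 24 h, tested at 10 uM; a higher number here means more inhibition of growth at the concentration tested, a lower number less inhibition of growth; compound 2 `CS(=O)(=O)c1ccc(-c2cnc3[nH]cc(-c4nnc(-c5ccc(F)cc5)o4)c(=O)c3c2)cc1`: 15.7%; compound 3 `CS(=O)(=O)c1ccc(-c2cnc3[nH]cc(-c4nnc(-c5ccccc5)o4)c(=O)c3c2)cc1`: 17.5%.

Compound 1 gives the largest of the three numbers, yet nothing separates it from the others: a number 0.9 percentage points lower from compound 1 to compound 3 (within the scatter) and a number 2.7 percentage points lower from compound 1 to compound 2 (within the scatter) both sit within the scatter, as does a number 1.8 percentage points higher from compound 2 to compound 3 (within the scatter). Compound 4 `Cc1cccc(-c2nnc(-c3c[nH]c4ncc(-c5ccc(S(C)(=O)=O)cc5)cc4c3=O)o2)c1` differs from compound 1 in one place, (3-methylphenyl in place of pyridin-4-yl on an aromatic carbon). The two measured steps that also swap the aryl group at this position, from compound 1 to compound 2 and from compound 1 to compound 3, moved nothing beyond the scatter, so no step beyond the scatter is expected in this assay here either. Compound 4 is accordingly estimated at 17%, between 8% and 27%, an expected step of a number 1.4 percentage points lower from compound 1 to compound 4 (within the scatter).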

Compound 4, percent growth inhibition at one concentration: 2.57%
For compound 4 the middle estimate is 14.4 percentage points above the measured one, and the stated range ends above it.
By their numbers in this assay, from the lowest: compound 4; then compounds 2, 3 and 1 (each within the scatter of the next).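

In this assay this position turns out not to be indifferent to the aryl group: the change to 3-methylphenyl gives a number 15.8 percentage points lower from compound 1 to compound 4 (beyond the scatter) and likewise a number 13.1 percentage points lower from compound 2 to compound 4 (beyond the scatter). The smallest change tells the most, since methyl in place of hydrogen on an aromatic carbon alone gives a number 14.9 percentage points lower from compound 3 to compound 4 (beyond the scatter), a step that pyridin-4-yl, 4-fluorophenyl and phenyl gave no hint of. Nothing available explains this drop.

Still open, from the compounds shown here alone, is whether only methyl lowers the number this way, or whether a methoxy group, a chlorine atom or an amine on the same phenyl ring would do the same.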